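This account rests on a few compounds, and the source may have more. Where it says the series, first, only, none or still open, it means among the compounds named here.

Measured compounds in this series:

- compound 1 `N[C@H]1CCc2nc(-c3ccncc3)nc(Nc3cccc(F)c3)c2C1`: 17900 nM
- compound 2 `CN(C)c1ccc(Nc2nc(-c3ccncc3)nc3c2CC(N)CC3)cc1`: 11500 nM
- compound 3 `N[C@@H]1CCc2nc(-c3ccncc3)nc(Nc3cccc(F)c3)c2C1`: 11100 nM

In a functional assay on DU-145 cells (Homo sapiens) for antiproliferative activity, read by MTT assay, with a stated time of 72 h (on this read-out lower numbers stand for stronger inhibition and higher numbers for weaker inhibition), compound 2 gives 11500 nM, which is the second highest of the three numbers. Its nearest neighbour is compound 3 and the gap is within the scatter; its furthest is compound 1, and that gap is within the scatter as well. All three numbers therefore sit together, and no order can be read among them.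

Going by the values given here, the only step between two measured compounds is a 1.6-fold lower number from compound 1 to compound 3 (0.21 log units; within the scatter), and it rests on (the fact that compounds 1 and 3 differ only in the configuration as drawn). It says nothing about a change on the aromatic ring that carries the amino link to the shared core.

Compound 4 `NC1CCc2nc(-c3ccncc3)nc(Nc3ccc(F)cc3)c2C1` is the next compound to be measured. Relative to compound 2 the change is fluoro in place of dimethylamino on an aromatic carbon; the fluoro sits on the ring para to a large group, with the stereocentre of the saturated ring left undefined. Among the compounds with values here, no measured step bears on this change. The values of compounds 1 and 3, which also carry a fluoro on that ring, fall within the scatter of compound 2, so no step beyond the scatter is expected in this assay in either direction.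

Compound 4 is estimated at 13000 nM, with a range of 5000 nM to 35000 nM, a step of a 1.1-fold higher number from compound 2 to compound 4 (0.05 log units; within the scatter) expected.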

Compound 4, half-maximal inhibitory concentration in the DU-145 assay: 10500 nM
Compound 4: middle estimate off by 1.2-fold (0.09 log units), on the high side; the measured number falls inside the stated range.
By their numbers in the DU-145 assay, from the lowest: compounds 4, 3, 2 and 1 (each within the scatter of the next).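

Going by these compounds alone, in the DU-145 assay, the first measured step on this aromatic ring, 4-(dimethylamino)phenyl to 4-fluorophenyl, is a 1.1-fold lower number from compound 2 to compound 4 (0.04 log units; within the scatter), so this exchange of dimethylamino for fluoro, para to a large group, leaves the number within the scatter, whereas the earlier step covered only a difference in drawn configuration. In a physicochemical assay for solubility, read by HPLC, in phosphate buffer, measured as kinetic solubility, with a stated time of 24 h, at pH 7.4 (on this read-out lower numbers stand for lower solubility and higher numbers for higher solubility), compound 2 gives > 250000 nM, which is a limit of the assay and not a number. In the physicochemical assay compound 4 gives > 250000 nM, again a limit and not a number, so the step for this change cannot be read: the limit of > 250000 nM in the physicochemical assay, at which 2 of the 2 values shown sit.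

On these data alone, whether a carboxylic acid or a longer chain on the same aromatic carbon would give a step beyond the scatter in the DU-145 assay stays open, as does any comparison in the physicochemical assay that would need a readable value rather than a limit. Also open, as far as these compounds go, is whether the two configurations at the saturated ring carbon differ when the aromatic ring is 4-fluorophenyl, since the stereocentre in compound 4 is undefined.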